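Series notes: compound 4 as ester analogue of compound 2

The compounds below may be only part of what the source reports. "The series", "measured", "known", "first", "only" and "open" are said of these compounds alone.

Measured so far in a functional assay on KB cells (Homo sapiens) for inhibition, read by colorimetric assay, with a stated time of 72 h; a lower number here means that less compound is needed, a higher number that more compound is needed for the effect:
compound 1, `CC1=C(C)C(=O)c2nn(Cc3ccccc3)nc2C1=O`: 3.5 ug/mL
compound 2, `Cc1cc2c(cc1C)[n+]([O-])nn2C`: > 100 ug/mL
compound 3, `COC(=O)C(C)n1nc2c(n1)C(=O)C(C)=C(C)C2=O`: 3.5 ug/mL

In this assay compound 1 gives 3.5 ug/mL and compound 3 gives 3.5 ug/mL; the two lie within the usual scatter of each other. Compound 2 gives only a limit, > 100 ug/mL, that is the limit of > 100 ug/mL in this assay, at which 1 of the 3 values shown sits. Compound 2 therefore stands apart from the other two measured compounds, which share a core that compound 2 does not have.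

Compound 4, `COC(=O)Cn1n[n+]([O-])c2cc(C)c(C)cc21`, has not yet been measured in this assay. It keeps the core of compound 2 and differs from it by methoxycarbonyl in place of hydrogen on a saturated chain carbon bound to an aromatic nitrogen. For the measured compounds named here, no measured pair differs in one place, so no step size is known from the data. The change is expected to give no step beyond the scatter, i.e. an expected a number no higher from compound 2 to compound 4 (the limit leaves the size open). For compound 4 the estimate in this assay is 100 ug/mL, with a range from 30 ug/mL to 300 ug/mL, and a real chance that only a limit is reported again.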

Compound 4, concentration for half-maximal effect: > 100 ug/mL
Compound 4: no number, only a limit; the forecaster's own chance of this, stated with the estimate: 70%; the middle value sits exactly at the limit.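

No step between compound 2 and compound 4 can be read in this assay, since both compounds give only a limit: the limit of > 100 ug/mL in this assay, at which 2 of the 4 values shown sit.

The compounds shown leave open whether methoxycarbonyl in place of hydrogen on a saturated chain carbon bound to an aromatic nitrogen changes the value at all.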